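This account rests on a few compounds, and the source may have more. Where it says the series, first, only, none or still open, it means among the compounds named here.

Series notes on the step from compound 3 to compound 4. Compound 1 `O=[N+]([O-])c1ccc(CN2CCC(n3cc(CC(OCc4cc(-c5ccccc5)no4)c4ccc(Br)cc4)nn3)CC2)cc1` and compound 2 `O=[N+]([O-])c1ccc(CN2CCC(n3cc(CC(OCc4cc(-c5cccc(F)c5)no4)c4ccc(Br)cc4)nn3)CC2)cc1` give, in a functional assay on MDA-MB-468 cells (Homo sapiens) for cytotoxicity, with a stated time of 48 h (on this read-out lower numbers stand for stronger inhibition and higher numbers for weaker inhibition), 3000 nM for compound 1 and 3000 nM for compound 2, with no change at the digits printed from compound 1 to compound 2 (within the scatter). Compound 3 `O=[N+]([O-])c1ccc(CN2CCC(n3cc(CC(OCc4cc(-c5ccccc5Br)no4)c4ccc(Br)cc4)nn3)CC2)cc1` gives only a limit in this assay, > 25000 nM. On the numbers shown compound 3 stands at the weak end, as the limit of > 25000 nM in this assay, at which 1 of the 3 values shown sits, marks. The steps of an at least 8.3-fold higher number from compound 1 to compound 3 (0.92 log units; beyond the scatter) and an at least 8.3-fold higher number from compound 2 to compound 3 (0.92 log units; beyond the scatter) both run toward weaker inhibition. Compound 4 `COc1ccccc1-c1cc(COC(Cc2cn(C3CCN(Cc4ccc([N+](=O)[O-])cc4)CC3)nn2)c2ccc(Br)cc2)on1` differs from compound 3 by methoxy in place of bromo on an aromatic carbon, ortho to a large group. Going by the values given here, no measured step exchanges bromo for methoxy, so the expected step of an at least 2.0-fold lower number from compound 3 to compound 4 (0.31 log units; beyond the scatter) is put at a modest gain at most. Compound 4 is estimated at 12000 nM, within 3000 nM to 30000 nM.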

Compound 4, half-maximal inhibitory concentration: > 25000 nM
Compound 4 was reported as a limit (the forecaster's own chance of this, stated with the estimate: 40%); middle value at least 2.0-fold (0.31 log units) away from the limit.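

In this assay, the 2-methoxyphenyl compound shows an at least 8.3-fold higher number from compound 1 to compound 4 (0.92 log units; beyond the scatter) and an at least 8.3-fold higher number from compound 2 to compound 4 (0.92 log units; beyond the scatter), so the loss seen with 2-bromophenyl is not confined to bromo. Both compounds are reported only as limits, so the step from compound 3 to compound 4 cannot be read and methoxy and bromo cannot be ranked at this position. Compound 3 and compound 4 now stand together at the weak end: the limit of > 25000 nM in this assay, at which 2 of the 4 values shown sit.

From the compounds shown here alone, whether a methyl or an amine on this carbon, ortho to a large group, would give the same loss remains open. Going by these compounds, the true potency of compound 3 and compound 4 also remains open.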